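The source may hold more compounds than are shown below. What is called first, only, known or untested is meant among the compounds shown, and "the series" means these compounds.

Within the data shown here, in a functional assay on COLO 205 cells (Homo sapiens) for antiproliferative activity, read by MTT assay, with a stated time of 68 h (on this read-out lower numbers stand for stronger inhibition and higher numbers for weaker inhibition), compound 2 `O=S(=O)(Nc1ccc(F)c(C#Cc2cnc3[nH]ncc3c2)c1F)c1cccnc1` gives 445 nM, the lowest of the two numbers measured so far, and its nearest neighbour is compound 1 `O=S(=O)(Nc1ccc(F)c(C#Cc2cnc3[nH]ncc3c2)c1F)c1ccccn1`, which in this assay gives 2670 nM. Among the measured compounds shown here, the single measured step, a 6.0-fold lower number from compound 1 to compound 2 (0.78 log units; beyond the scatter), concerns only the group on the sulfonyl sulfur. Compound 3 `O=S(=O)(Nc1ccc(F)c(C#Cc2cnc3[nH]nc(-c4ccccc4Cl)c3c2)c1F)c1cccnc1` differs from compound 2 elsewhere: 2-chlorophenyl in place of hydrogen on an aromatic carbon. For the measured compounds named here, no measured step touches this part of the shared core, so the step from compound 1 to compound 2 gives no direct guide to the size or direction of the new step and shows only that single changes can move the number beyond the scatter. With that caveat, compound 3 is expected to give about 200 nM in this assay, within a wide range of 30 nM to 1500 nM, a change estimated as a 2.2-fold lower number from compound 2 to compound 3 (0.35 log units; beyond the scatter) and held with little confidence.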

Compound 3, half-maximal inhibitory concentration: 3600 nM
Compound 3: middle estimate off by 18-fold (1.26 log units), on the low side; measured number outside the range, above it.
By their numbers in this assay, from the lowest: compound 2; then compounds 1 and 3 (each within the scatter of the next).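

Within this assay the aromatic carbon of the five-membered ring with 2 nitrogen, which no earlier step touched, proves sensitive to substitution: 2-chlorophenyl in place of hydrogen gives an 8.1-fold higher number from compound 2 to compound 3 (0.91 log units; beyond the scatter) and so weakens inhibition. Among the two groups shown at this position, hydrogen therefore gives the lower number, and this change moves the number by about as much as the change on the sulfonyl sulfur does, though in the opposite direction. No measurement available here bears on why this step occurs.

On these data alone, whether a smaller group such as methyl or an amine, or a phenyl without the chlorine, would hold the number of compound 2 remains open. As far as these compounds go, it also remains open whether the step would be of the same size with pyridin-2-yl on the sulfonyl sulfur.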